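The compounds below may be only part of what the source reports. "The series", "measured", "known", "first", "only" and "open" are said of these compounds alone.

Three compounds have been measured in a functional assay on MCF7 cells (Homo sapiens) for antiproliferative activity, read by CellTiter-Glo, with a stated time of 5 days (on this read-out higher numbers stand for weaker inhibition and lower numbers for stronger inhibition), so far:
compound 1 `CC/C(=C(/c1ccc(/C=C/C(=O)O)cc1)c1ccn2nccc2c1)c1ccccc1` gives > 500 nM as a limit
compound 2 `CC/C(=C(/c1ccc(/C=C/C(=O)O)cc1)c1ccc2scnc2c1)c1ccccc1` gives 90 nM as a number
compound 3 `CC/C(=C(/c1ccc(/C=C/C(=O)O)cc1)c1ccc(-c2cscn2)cc1)c1ccccc1` gives 120 nM as a number

The value of compound 1 is a limit and not a number. Compound 3 stands at 120 nM in this assay and lies within the usual scatter of compound 2 (90 nM) so these two cannot be told apart.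

Compound 4 `CC/C(=C(/c1ccc(/C=C/C(=O)O)cc1)c1ccc(-n2ccnc2)cc1)c1ccccc1` differs from compound 3 in one group (1H-imidazol-1-yl in place of 1,3-thiazol-4-yl on an aromatic carbon) with 1H-imidazol-1-yl in place of 1,3-thiazol-4-yl on an aromatic carbon. Among the compounds with values here, no measured step makes this exact swap. The one that bears on it, and only loosely, is the step of an at least 5.5-fold lower number from compound 1 to compound 2 (0.74 log units; beyond the scatter) in which a group holding sulfur took the place of one without sulfur. That step involved different groups, and it is a single case. Here sulfur leaves, so the reverse direction is expected, but with a smaller size and much uncertainty. The estimated step is a 1.8-fold higher number from compound 3 to compound 4 (0.26 log units; within the scatter) as a modest move towards weaker inhibition that may not clear the scatter. Compound 4 is expected at 220 nM with an estimated range from 70 nM to 700 nM in this assay once it is measured.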

Compound 4, half-maximal inhibitory concentration: 380 nM
Compound 4: the middle estimate sits 1.7-fold (0.24 log units) below what was measured; the range from low to high includes it.
By their numbers in this assay, from the lowest: compounds 2 and 3 (each within the scatter of the next); then compound 4. At a limit, above all of these: compound 1.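

At this place, on an aromatic carbon of a six-membered aromatic ring of carbon only and para to a large group, this assay shows a 3.2-fold higher number from compound 3 to compound 4 (0.50 log units; beyond the scatter) when 1H-imidazol-1-yl takes the place of 1,3-thiazol-4-yl. The two groups match in every count given: the same number of heavy atoms, hydrogen-bond donors and acceptors, one five-membered aromatic ring with 2 hetero atoms and no net charge. The read-out therefore separates them on something those counts do not capture. Compound 4 still gives a number, so this swap moves inhibition towards weaker values without reaching the limit seen so far: the limit of > 500 nM in this assay, at which 1 of the 4 values shown sits.

Which part of the swap matters stays open, whether the sulfur leaving, the second nitrogen entering or the ring being attached through nitrogen instead of carbon; the one step changes all of these together, and no measured property of either group is given. Also open, from the compounds shown here alone, is whether 1,3-oxazol-4-yl, 1H-pyrazol-1-yl or a plain phenyl at this place would read like compound 3 or like compound 4, and whether the gap would hold with an amide in place of the carboxylic acid.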